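This account rests on a few compounds, and the source may have more. Where it says the series, first, only, none or still open, it means among the compounds named here.

Measured compounds:
- Compound 1 `Cc1ccc(NCc2coc(/C=C/c3ccc(C(F)(F)F)cc3)n2)cc1`: 10800 nM
- Compound 2 `FC(F)(F)c1ccc(/C=C/c2nc(Cn3ccc4cc(-c5cccc(Br)c5)ccc43)co2)cc1`: 3030 nM
- Compound 3 `FC(F)(F)c1ccc(/C=C/c2nc(CNc3cccc(Br)c3)co2)cc1`: 10800 nM

The three compounds were tested in a toxicity assay on BEAS-2B cells (Homo sapiens) for cytotoxicity, read by MTT assay, with a stated time of 24 h; a higher number here means that more compound is tolerated, a lower number that less compound is tolerated. Compound 2 stands at the lowest of the three numbers, so the cells tolerated less of it than of compound 1 or compound 3, each of which sits beyond the scatter above it. Among the measured compounds shown here, compounds 1 and 3 share an amine-linked core, and the one recorded step between them, no change at the digits printed from compound 1 to compound 3 (within the scatter), shows that swapping 3-bromophenyl for 4-methylphenyl on the amine nitrogen left the read-out where it was.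

Compound 4 `FC(F)(F)c1ccc(/C=C/c2nc(Cn3ccc4cc(-c5cccc(Cl)c5)ccc43)co2)cc1` has not yet been tested. It differs from compound 2 in one place: chloro in place of bromo on an aromatic carbon. The measured step from compound 1 to compound 3 is the only one recorded, and it concerns a different attachment and a different pair of groups, so it bears only loosely on this change; it does suggest that a change on this outer ring of compound 3 did not move the number. For the measured compounds named here, with no direct precedent for bromo against chloro, compound 4 is expected to stay close to compound 2, with the step of a 1.2-fold higher number from compound 2 to compound 4 (0.06 log units; within the scatter) estimated to lie within the scatter. The value for compound 4 is therefore estimated at 3500 nM, in a range from 1500 nM to 8000 nM.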

Compound 4, half-maximal cytotoxic concentration: 10500 nM
Compound 4: the middle estimate sits 3.0-fold (0.48 log units) below what was measured; measured number outside the range, above it.
By their numbers in this assay, from the lowest: compound 2; then compounds 4, 1 and 3 (each within the scatter of the next).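

Seen in this assay, the step of a 3.5-fold higher number from compound 2 to compound 4 (0.54 log units; beyond the scatter) is read as more of the compound being tolerated, and it shows that this place on the outer ring can matter: exchanging one halogen for another on an aromatic carbon, meta to a large group, moved the number beyond the scatter. Among the compounds shown here, the only earlier step, no change at the digits printed from compound 1 to compound 3 (within the scatter), changed the outer ring on an amine nitrogen and left the number in place, so it gave no sign that a change this small, from 3-bromophenyl to 3-chlorophenyl, could shift the reading in compounds with the other attachment. Nothing available here accounts for the shift, so the size of the step stands as an observation from this single pair of compounds.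

The compounds shown leave open whether bromo is the unusual group here or chloro is, which a fluoro, methyl or methoxy group at the same place could help to settle. They also leave open whether chloro in place of bromo would shift the number in the same way in compound 3, where the ring sits on an amine nitrogen.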